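The source may hold more compounds than are shown below. What is called first, only, known or untested is meant among the compounds shown, and "the series" means these compounds.

Measured compounds:
Compound 1, `CN(CCCc1ccccc1)Cc1cn(CC(O)COCc2ccccc2)nn1`, gives 18% in an assay on nucleic acid for inhibition of Nucleic Acid, read by fluorescence, tested at 100 uM; a lower number here means less inhibition, a higher number more inhibition at the concentration tested (going by the name of the read-out).
Compound 2, `CCCCCCCC(=O)OCC(O)Cn1cc(CN(CCCC)CCCC)nn1`, gives 71% in this assay.
Compound 3, `CN(Cc1cn(CC(O)COCc2ccccc2)nn1)CC1CCCCC1`, gives 6% in this assay.

Among the compounds with values here, compound 1 stands second highest of the three numbers; its nearest neighbour is compound 3, and the one step that has been measured, a number 12 percentage points lower from compound 1 to compound 3 (beyond the scatter), runs through the amine side of the molecule. Compound 2, with its octanoate ester and dibutylamine, stands far higher, but it differs from compound 1 in more than one place, so its value shows only that much larger inhibition is possible in this series.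

Compound 4, `CCCCC(O)Cn1cc(CN(C)CCCc2ccccc2)nn1`, is reached from compound 1 by a change on the other side: propyl in place of benzyloxy on a saturated chain carbon, two bonds along the chain from an oxygen on a saturated carbon. Within the data shown here, no measured step touches that side, so the measured step from compound 1 to compound 3 does not bear on it directly; it only shows that a single change can move the number modestly. The expected step is therefore small, a number 3 percentage points lower from compound 1 to compound 4 (within the scatter), with no clear direction beyond the scatter. Compound 4 is estimated at 15%, within 0% to 35%.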

Compound 4, a percentage reported as inhibition, at one concentration (the size of the read-out at that concentration, not a potency): 37%
Estimate against measurement, compound 4: 22 percentage points below; the whole stated range lies below it.
By their numbers in this assay, from the lowest: compound 3; then compound 1; then compound 4; then compound 2.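

In this assay, the place on a saturated chain carbon, two bonds along the chain from an oxygen on a saturated carbon, now has a measured step of its own: propyl in place of benzyloxy gives a number 19 percentage points higher from compound 1 to compound 4 (beyond the scatter) and shows that this side of the molecule can also move the number. The change takes away the six-membered aromatic ring and the oxygen of benzyloxy together, and the number still rises, so neither is required for the inhibition seen at the concentration tested. Nothing at hand explains the rise.

The compounds shown leave open whether the ring or the oxygen carries the step, the one change removing both. They also leave open how a longer chain, a methoxy group or an amine would read at this place.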